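Cyanoguanidine and thiourea chain variants on a shared pyridazinone core

A few compounds are considered here, and "the series" means these few. Any claim that something is new, unique, unknown or untested is made for them only; others in the source may bear on it.

Measured so far:
compound 1, `CN(C)/C(=N/CCCCn1nc(-c2ccccc2)ccc1=O)NC#N`, 52.9 mg/kg
compound 2, `C/N=C(\S)NCCCCCn1nc(-c2ccccc2)ccc1=O`, 42.1 mg/kg
compound 3, `CC/N=C(/NC#N)NCCCCn1nc(-c2ccccc2)ccc1=O`, 60.7 mg/kg

In a functional assay on the whole organism with Rattus norvegicus as the target (a lower number here means that less compound is needed, a higher number that more compound is needed for the effect), compound 3 gives the highest of the three numbers, but only just: a 1.1-fold higher number from compound 1 to compound 3 (0.06 log units; within the scatter) and a 1.4-fold higher number from compound 2 to compound 3 (0.16 log units; within the scatter) are both small, so compound 3 cannot be told apart from compound 1 or compound 2 on these numbers. Compound 4, `C/N=C(/NC#N)NCCCCCn1nc(-c2ccccc2)ccc1=O`, is not yet measured. It differs from compound 3 by a group of 8 heavy atoms (4 carbon, 4 nitrogen; no ring) in place of a group of 8 heavy atoms (4 carbon, 4 nitrogen; no ring), on a saturated chain carbon, four bonds along the chain from an aromatic nitrogen; the two share the same atoms, joined differently. For the measured compounds named here, the steps that bear on this are the ones among compounds 1, 2 and 3, all within the scatter: a 1.3-fold lower number from compound 1 to compound 2 (0.10 log units; within the scatter), a 1.1-fold higher number from compound 1 to compound 3 (0.06 log units; within the scatter), a 1.4-fold higher number from compound 2 to compound 3 (0.16 log units; within the scatter). Going by the values given here, every exchange of the terminal group so far, including the one that changes chain length and sulfur content, has left this assay flat. No step beyond the scatter is therefore expected for compound 4, in either direction, and the estimate for compound 4 is 52 mg/kg, range 30 mg/kg to 95 mg/kg, meaning a 1.2-fold lower number from compound 3 to compound 4 (0.07 log units; within the scatter) as the expected step.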

Compound 4, dose for half-maximal effect: 76.2 mg/kg
Beside the measured number, compound 4's estimate is 1.5-fold (0.17 log units) below it; the measured number falls inside the stated range.
By their numbers in this assay, from the lowest: compounds 2, 1, 3 and 4 (each within the scatter of the next).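

In this assay, rejoining the same atoms on a saturated chain carbon, four bonds along the chain from an aromatic nitrogen, gives a 1.3-fold higher number from compound 3 to compound 4 (0.10 log units; within the scatter), so this rearrangement does not separate compound 3 from compound 4. The exchanges from the other two compounds read the same way, with a 1.4-fold higher number from compound 1 to compound 4 (0.16 log units; within the scatter) and, on an amine nitrogen, a 1.8-fold higher number from compound 2 to compound 4 (0.26 log units; within the scatter), the widest step in the set and still not a resolved difference. No measurement at hand explains why these numbers fall where they do.

From the compounds shown here alone, a longer chain remains open, as does whether an amine or a carboxylic acid as the terminal group would give a step beyond the scatter. The compounds shown also leave open whether any change at this position can move the number in this assay at all.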